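Reading the step from compound 3 to compound 4

The compounds below may be only part of what the source reports. "The series", "measured", "known", "first", "only" and "open" are said of these compounds alone.

Measured in a functional assay on MDA-MB-231 cells (Homo sapiens) for inhibition, read by MTT assay, with a stated time of 48 h; on this read-out higher numbers stand for weaker inhibition of growth and lower numbers for stronger inhibition of growth:
- Compound 1 (`NS(=O)(=O)c1ccc(NC(=S)Nc2ccc3ncnc(Nc4cccc(Br)c4)c3c2)cc1`): > 30000 nM (a limit of the assay)
- Compound 2 (`FC(F)(F)c1cc(NC(=S)Nc2ccc3ncnc(Nc4cccc(Br)c4)c3c2)ccc1Cl`): 1100 nM
- Compound 3 (`FC(F)(F)c1ccc(NC(=S)Nc2ccc3ncnc(Nc4cccc(Br)c4)c3c2)cc1`): 12200 nM

Compound 3, at 12200 nM, holds the higher of the two actual numbers. The entry for compound 1 is only a limit. Compound 4 (`S=C(Nc1ccc(Br)cc1)Nc1ccc2ncnc(Nc3cccc(Br)c3)c2c1`) differs from compound 3 in one place (bromo in place of trifluoromethyl on an aromatic carbon): bromo in place of trifluoromethyl on an aromatic carbon, para to a large group.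

Within the data shown here, no measured step makes this exact swap. Two bear on it indirectly: the large 11-fold higher number from compound 2 to compound 3 (1.04 log units; beyond the scatter) and the at least modest an at least 2.4-fold lower number from compound 1 to compound 3 (0.39 log units; beyond the scatter). Both show that changes on this ring can move the number beyond the scatter. Yet compound 4 keeps one group at the same place, as compound 3 does at 12200 nM, so no large move is expected.

The expected result is a 1.2-fold lower number from compound 3 to compound 4 (0.09 log units; within the scatter), an estimated step that stays within the scatter. Compound 4 is estimated at 10000 nM, with an expected range from 4000 nM to 30000 nM in this assay as the assay that will decide.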

Compound 4, concentration for 50% growth inhibition: > 30000 nM
Compound 4 gave a limit, no number (the forecaster's own chance of this, stated with the estimate: 15%); middle value at least 3.0-fold (0.47 log units) away from the limit.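

In this assay, bromo in place of trifluoromethyl gives an at least 2.4-fold higher number from compound 3 to compound 4 (0.39 log units; beyond the scatter), so the step on this aromatic carbon moves the result beyond the scatter even though a single group still sits there. Losing the 4-chloro-3-(trifluoromethyl)phenyl group as well gives a far larger change, an at least 27-fold higher number from compound 2 to compound 4 (1.43 log units; beyond the scatter). Compound 1 and compound 4 each give a limit, not a number, so the step between them cannot be read: the limit of > 30000 nM in this assay, at which 2 of the 4 values shown sit.

Still open, as far as these compounds go, is how a methoxy group, an amine or a carboxylic acid on this same carbon would read in this assay, and whether any of them would come close to compound 2. From the compounds shown here alone, the true size of both readable steps ending at compound 4 also stays open, as only their minimum is known.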